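The compounds below may be only part of what the source reports. "The series", "measured", "known", "first", "only" and "open" are said of these compounds alone.

Measured so far in an ADME assay on Raji cells (Homo sapiens) for cytotoxicity, read by luminescence, with a stated time of 72 h; on this read-out higher numbers stand for an effect only at larger amounts of compound and lower numbers for an effect already at smaller amounts:
Compound 1 (`CCOC(=O)c1c(-c2cccc(OCC)c2)[nH]c2cc(OC)ccc2c1=O`) gives > 21500 nM as a limit.
Compound 2 (`CCOC(=O)c1c(-c2cccc(F)c2)[nH]c2cc(OC)ccc2c1=O`) gives > 21500 nM as a limit.
Compound 3 (`CCOC(=O)c1c(-c2cccc(C(C)=O)c2)[nH]c2cc(OC)ccc2c1=O`) gives > 21500 nM as a limit.

Compound 3 has no number of its own, only the limit > 21500 nM as its reading. The other two compounds stand at the same place (the limit of > 21500 nM in this assay, at which 3 of the 3 values shown sit).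

The next compound, compound 4 (`CCOC(=O)c1c(-c2cccc(CO)c2)[nH]c2cc(OC)ccc2c1=O`), carries hydroxymethyl in place of acetyl on an aromatic carbon, meta to a large group (hydroxymethyl in place of acetyl on an aromatic carbon).

Three measured exchanges at this carbon bear on the change: (a step that the two limits leave unreadable from compound 1 to compound 2), (a step that the two limits leave unreadable from compound 1 to compound 3) and (a step that the two limits leave unreadable from compound 2 to compound 3). None of them has a readable size, so they give no direction.

Since compound 3 reads > 21500 nM as a limit, no step beyond the scatter is expected in this assay for this exchange. The expected step is a number no higher from compound 3 to compound 4 (the limit leaves the size open) as an estimate only. For compound 4 the estimated value is 21500 nM with an expected range from 8000 nM to 30000 nM and a report as a limit once more is the likely outcome.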

Compound 4, half-maximal effective concentration: > 21500 nM
Compound 4: a limit, no number; the forecaster's own chance of this, stated with the estimate: 85%; the middle value lies on the limit itself.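

In this assay, within the data shown here, compound 4 gives > 21500 nM, a limit and not a number, and no step linking it to compound 1, compound 2 or compound 3 can be read. The compounds shown leave open whether any of these exchanges changes the read-out at all: the limit of > 21500 nM in this assay, at which 4 of the 4 values shown sit.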